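Aryl Triazoles Against a Gastric Carcinoma Cell Line

The source may report more compounds than this note shows. Statements on the series, on what has been measured and on what is new or still open speak of the compounds shown alone.

Measured compounds:
compound 1, `CC1=C(CCCCCCCCCCn2cc(C[C@H](O)COCCOC[C@@H](O)Cc3ccc(-c4ccccc4)cc3)nn2)C(=O)c2ccccc2C1=O`, 390 nM
compound 2, `COC1=C(OC)C(=O)C(CCCCCCCCCCn2cc(C[C@H](O)COCCOC[C@@H](O)Cc3ccc(-c4ccccc4)cc3)nn2)=C(C)C1=O`, 3800 nM
compound 3, `O[C@H](COCCOC[C@@H](O)Cc1cn(-c2cncnc2)nn1)Cc1ccc(-c2ccccc2)cc1`, a limit of > 100000 nM

All three share the same diol-ether backbone ending in the biphenyl group and a triazole ring; they differ in what sits on the aromatic nitrogen of that ring. In a functional assay on SGC-7901 cells (Homo sapiens) for inhibition, read by MTT assay, with a stated time of 72 h (a lower number here means a stronger inhibitor of growth, a higher number a weaker inhibitor of growth), compound 1 gives 390 nM and compound 2 gives 3800 nM, and the two values show compound 2 as the weaker inhibitor of growth. For compound 3 this assay reports only a limit, > 100000 nM, so compound 3 stands at the weak end of the numbers shown, as the limit of > 100000 nM in this assay, at which 1 of the 3 values shown sits, records. Within the data shown here, compound 3 differs from compound 1 and from compound 2 in more than one place, so no single step links it to either.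

Compound 4, `O[C@H](COCCOC[C@@H](O)Cc1cn(-c2ccc3c(c2)OCCO3)nn1)Cc1ccc(-c2ccccc2)cc1`, differs from compound 3 by 2,3-dihydro-1,4-benzodioxin-6-yl in place of pyrimidin-5-yl on an aromatic nitrogen. Among the measured compounds shown here, no measured pair isolates such a change, so its size is unknown from these data. Since compound 3 sits at the limit, the writer expects no step beyond the scatter in this assay and a good chance that compound 4 again returns only a limit. The estimate for compound 4 is 80000 nM, from 20000 nM to 300000 nM, which means an expected step of an at least 1.2-fold lower number from compound 3 to compound 4 (0.09 log units; that floor lies within the scatter).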

Compound 4, concentration for 50% growth inhibition: 6400 nM
The estimate for compound 4 lay 13-fold (1.10 log units) above the measured number, outside the stated range (below it).
By their numbers in this assay, from the lowest: compound 1; then compounds 2 and 4 (each within the scatter of the next). At a limit, above all of these: compound 3.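

At this position, on an aromatic nitrogen of the triazole, the choice of ring decides whether growth inhibition can be read at all: in this assay, 2,3-dihydro-1,4-benzodioxin-6-yl in place of pyrimidin-5-yl gives an at least 15-fold lower number from compound 3 to compound 4 (1.19 log units; beyond the scatter). Among these compounds, this is the first single-place change, and it shows a clear response to the group on this nitrogen, even though the two groups have the same counts of hydrogen-bond donors and acceptors and neither carries a net charge; what differs is that the entering group is larger, with a carbon-only aromatic ring and a further non-aromatic ring. Compound 3 is recorded only as a limit, so the step has a floor but no measured size: the limit of > 100000 nM in this assay, at which 1 of the 4 values shown sits.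

The compounds shown leave open whether the non-aromatic ring with its two oxygens is needed, or whether a plain phenyl group on the same nitrogen would give a similar number. As far as these compounds go, it also remains open how an amine or a carboxylic acid on the aromatic ring of the 2,3-dihydro-1,4-benzodioxin-6-yl group would change the result.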